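The compounds below may be only part of what the source reports. "The series", "measured", "known", "first", "only" and "open" are said of these compounds alone.

Compound 2 `COc1cc(-c2nn(-c3cccc(NC(=O)Nc4ccc(Cl)c(Cl)c4)c3)cc2-c2ccncc2)ccc1Cl` gives 3110 nM in a functional assay on UACC-257 cells (Homo sapiens) for inhibition, read by sulforhodamine B assay, with a stated time of 48 h; on this read-out lower numbers stand for stronger inhibition of growth and higher numbers for weaker inhibition of growth. Its two neighbours sit within the usual scatter of it: compound 1 `COc1cc(-c2nn(-c3cccc(NC(=O)Nc4cc(C(F)(F)F)cc(C(F)(F)F)c4)c3)cc2-c2ccncc2)ccc1Cl` gives 2350 nM, and compound 3 `O=C(Nc1cccc(-n2cc(-c3ccncc3)c(-c3ccc(Cl)c(O)c3)n2)c1)Nc1ccc(Cl)c(Cl)c1` gives 3160 nM. Going by the values given here, the one measured step, a 1.0-fold higher number from compound 2 to compound 3 (0.01 log units; within the scatter), shows that removing the methyl from the oxygen changes nothing beyond the scatter. Compound 4 `COc1cc(-c2nn(-c3cccc(NC(=O)c4ccc(Cl)c(C(F)(F)F)c4)c3)cc2-c2ccncc2)ccc1Cl` differs from compound 2 by 4-chloro-3-(trifluoromethyl)phenyl in place of (3,4-dichlorophenyl)amino on a carbonyl carbon. Among the compounds with values here, no measured step covers this change: the link from the amide-type nitrogen to the aryl ring loses its nitrogen-hydrogen, and the ring substituents shift. Compound 1 and compound 2 differ in their halogenated aryl rings yet sit within scatter, so for compound 4 the expected step is a 1.0-fold lower number from compound 2 to compound 4 (0.02 log units; within the scatter), and compound 4 is estimated at 3000 nM with a range of 1000 nM to 9000 nM.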

Compound 4, concentration for total growth inhibition: > 32500 nM
Compound 4 was reported as a limit; the forecaster's own chance of this, stated with the estimate: 5%; middle value at least 10-fold (1.03 log units) from the limit.
By their numbers in this assay, from the lowest: compounds 1, 2 and 3 (each within the scatter of the next). At a limit, above all of these: compound 4.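

Replacing (3,4-dichlorophenyl)amino on the carbonyl carbon with 4-chloro-3-(trifluoromethyl)phenyl gives an at least 10-fold higher number from compound 2 to compound 4 (1.01 log units; beyond the scatter) in this assay. The earlier compounds shown here varied only the aryl ring or the methyl on the oxygen and stayed close together, whereas this change, which also removes the nitrogen and its hydrogen, costs a large loss of growth inhibition. Compound 4 is reported as a limit, not a number: the limit of > 32500 nM in this assay, at which 1 of the 4 values shown sits.

This single change alters both the link and the ring substituents, so the compounds shown cannot separate the two. Also open, as far as these compounds go, is how a (3,4-dichlorobenzyl) group or a cyclohexylamino group on that carbonyl carbon would behave.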